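Moving the trifluoromethyl group around the benzyl ring

The compounds below may be only part of what the source reports. "The series", "measured", "known", "first", "only" and "open" are said of these compounds alone.

Compound 1 `O=C(NCCO)c1cccc2c1CCN2c1cc(Cc2cc(F)cc(C(F)(F)F)c2)ncn1`: 135 nM
Compound 2 `O=C(NCCO)c1cccc2c1CCN2c1cc(Cc2ccccc2C(F)(F)F)ncn1`: 711 nM

Going by the values given here, in a functional assay on HEK293 cells for agonist activity at G-protein coupled receptor 52 (Homo sapiens), read by cAMP accumulation, with a stated time of 15 min (a higher number here means that more compound is needed for the effect, a lower number that less compound is needed), compound 2 has the highest number of the two measured compounds; the only other is compound 1, which lies a 5.3-fold higher number from compound 1 to compound 2 (0.72 log units; beyond the scatter) away. Compound 3 `O=C(NCCO)c1cccc2c1CCN2c1cc(Cc2ccc(C(F)(F)F)cc2)ncn1` differs from compound 2 only in this way: 4-(trifluoromethyl)phenyl in place of 2-(trifluoromethyl)phenyl on a saturated chain carbon bound to an aromatic carbon. Among the compounds with values here, the single measured step, from compound 1 to compound 2 (a 5.3-fold higher number from compound 1 to compound 2 (0.72 log units; beyond the scatter)), shows that where the substituents sit on that ring changes the number well beyond the scatter, but no measured pair speaks to the 4-position directly. Compound 3 is therefore expected to land somewhere near compound 2, with a 1.4-fold lower number from compound 2 to compound 3 (0.15 log units; within the scatter) as the estimated step, giving an estimate of 500 nM with a range of 120 nM to 2500 nM.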

Compound 3, half-maximal effective concentration: 109 nM
Estimate against measurement, compound 3: 4.6-fold (0.66 log units) above; the measured number lies below the stated range.
By their numbers in this assay, from the lowest: compounds 3 and 1 (each within the scatter of the next); then compound 2.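

In this assay, the place of the trifluoromethyl group on the benzyl ring alone moves the number: with the same atoms joined differently, 4-(trifluoromethyl)phenyl in place of 2-(trifluoromethyl)phenyl gives (a 6.5-fold lower number from compound 2 to compound 3 (0.81 log units; beyond the scatter)). The 4-(trifluoromethyl)phenyl of compound 3 and the 3-fluoro-5-(trifluoromethyl)phenyl of compound 1 are not separated (a 1.2-fold lower number from compound 1 to compound 3 (0.09 log units; within the scatter)), so among these three only compound 2 stands apart.

Going by these compounds, whether a nitrile or a methoxy group could stand in for the trifluoromethyl group of 4-(trifluoromethyl)phenyl remains open. Nothing available accounts for the difference between these ring placements.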